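Shifting the chlorine on the benzyl group

This account rests on a few compounds, and the source may have more. Where it says the series, first, only, none or still open, it means among the compounds named here.

Among the measured compounds shown here, compound 2 `O=c1ccc(-c2ccc3cn[nH]c3c2)cn1Cc1cccc(Cl)c1` gives 37 nM in an assay for inhibition of MAP kinase-interacting serine/threonine-protein kinase 1 (Homo sapiens), read by luminescence and ADP-Glo, with a stated time of 2 h (a lower number here means a stronger inhibitor, a higher number a weaker inhibitor), and is the only compound with a number rather than a limit. Compound 1 `O=C(N1CCOCC1)n1cc(-c2ccc3cn[nH]c3c2)ccc1=O` reports > 2000 nM in this assay, which is a limit (the limit of > 2000 nM in this assay, at which 1 of the 2 values shown sits). The measured step of an at least 54-fold lower number from compound 1 to compound 2 (1.73 log units; beyond the scatter) concerns the substituent on the aromatic nitrogen, not the chlorine position on the phenyl ring. Compound 3 `O=c1ccc(-c2ccc3cn[nH]c3c2)cn1Cc1ccccc1Cl` differs from compound 2 by 2-chlorophenyl in place of 3-chlorophenyl on a saturated chain carbon bound to an aromatic nitrogen. For the measured compounds named here, no measured step bears on this change, so the expected step of a 1.6-fold higher number from compound 2 to compound 3 (0.21 log units; within the scatter) in this assay is modest and toward a higher number. Compound 3 is estimated at 60 nM, between 15 nM and 250 nM.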

Compound 3, half-maximal inhibitory concentration: 80 nM
For compound 3 the middle estimate is 1.3-fold (0.12 log units) below the measured one; low and high end bracket the measured number.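

Moving the chlorine has a measurable cost: 2-chlorobenzyl in place of 3-chlorobenzyl gives a 2.2-fold higher number from compound 2 to compound 3 (0.33 log units; beyond the scatter), so this position responds to where the chlorine sits on the phenyl ring, not only to which group occupies the aromatic nitrogen. The 2-chlorobenzyl group still far outperforms the (morpholin-4-yl)carbonyl group, with an at least 25-fold lower number from compound 1 to compound 3 (1.39 log units; beyond the scatter). That step is read against a limit, not a number: the limit of > 2000 nM in this assay, at which 1 of the 3 values shown sits.

Open is whether the chlorine contributes at all, since a plain benzyl group is not among the compounds shown. Also open, going by these compounds, is how a longer chain carrying the phenyl ring would compare.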